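This account rests on a few compounds, and the source may have more. Where it says the series, first, only, none or still open, it means among the compounds named here.

Of the compounds shown here, two built on a shared core have been measured in an assay on HEK293 cells for displacement of a labelled ligand from adenosine receptor A2b (Homo sapiens), with a stated time of 30 min; on this read-out higher numbers stand for weaker inhibition and lower numbers for stronger inhibition. Compound 1 `CCOC(=O)C1=C(C)NC(=O)N(C(C)=O)C1c1ccco1` gives 3110 nM; compound 2 `CCOC(=O)C1=C(C)N(C)C(=O)NC1c1ccco1` gives 6540 nM, the higher of the two numbers, and its gap to compound 1 lies beyond the scatter. Compound 3 `CC1=C(C(=O)OC(C)C)C(c2ccco2)NC(=O)N1C` differs from compound 2 by methyl in place of hydrogen on a saturated chain carbon bound to an oxygen next to a carbonyl group and a saturated chain carbon, read one bond further out as ethoxycarbonyl to isopropoxycarbonyl. For the measured compounds named here, no measured pair shows this change, so its size cannot be taken from the data. The step expected here, a 1.1-fold lower number from compound 2 to compound 3 (0.04 log units; within the scatter), need not exceed the scatter in either direction. The estimate for compound 3 is 6000 nM, between 2500 nM and 14000 nM.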

Compound 3, inhibition constant: 1150 nM
For compound 3 the middle estimate is 5.2-fold (0.72 log units) above the measured one, and the stated range ends above it.
By their numbers in this assay, from the lowest: compound 3; then compound 1; then compound 2.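

In this assay, ethoxycarbonyl to isopropoxycarbonyl brings a 5.7-fold lower number from compound 2 to compound 3 (0.75 log units; beyond the scatter), so one added methyl at this place moves the number beyond the scatter. Compound 1 and compound 2 both carry ethoxycarbonyl, so neither could show that this place responds to change. Nothing available explains the size of this step. On these data alone, whether a longer chain such as butyl or a cyclopentyl ring here would lower the number further stays open, as does whether isopropoxycarbonyl would bring a similar step on the core of compound 1.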